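Swapping Trifluoromethyl for Trifluoromethoxy on the Shared Core

The source may hold more compounds than are shown below. What is called first, only, known or untested is meant among the compounds shown, and "the series" means these compounds.

Three measured compounds share one core and differ in where their hydroxy groups sit. Compound 1 (`Oc1cccc(-c2cc(-c3ccccc3C(F)(F)F)cc(-c3ccccc3O)n2)c1`) gives 5680 nM in a functional assay on T47D cells (Homo sapiens) for inhibition; a higher number here means a weaker inhibitor, a lower number a stronger inhibitor. Compound 2 (`Oc1ccc(-c2cc(-c3ccccc3C(F)(F)F)cc(-c3ccccc3O)n2)cc1`) gives 7180 nM in this assay and so stands at the higher of the two numbers, though the step of a 1.3-fold higher number from compound 1 to compound 2 (0.10 log units; within the scatter) is within the scatter, so the two cannot really be told apart. For compound 3 (`Oc1ccc(-c2cc(-c3ccccc3C(F)(F)F)cc(-c3ccc(O)cc3)n2)cc1`) only a limit is known, > 50000 nM, and this is the limit of > 50000 nM in this assay, at which 1 of the 3 values shown sits. The step of an at least 6.9-fold higher number from compound 2 to compound 3 (0.84 log units; beyond the scatter) is beyond the scatter.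

Compound 4 (`Oc1ccc(-c2cc(-c3ccccc3OC(F)(F)F)cc(-c3ccccc3O)n2)cc1`) differs from compound 2 by trifluoromethoxy in place of trifluoromethyl on an aromatic carbon. Neither measured step touches this group: both move hydroxy groups on other rings, so neither bears directly on the change. Without such guidance, the expectation for compound 4 is a step of a 1.1-fold higher number from compound 2 to compound 4 (0.05 log units; within the scatter) that stays within the scatter. Compound 4 is therefore estimated at 8000 nM in this assay, with a range from 3000 nM to 25000 nM.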

Compound 4, half-maximal inhibitory concentration: 2050 nM
For compound 4 the middle estimate is 3.9-fold (0.59 log units) above the measured one; the whole stated range lies above it.
By their numbers in this assay, from the lowest: compound 4; then compounds 1 and 2 (each within the scatter of the next). At a limit, above all of these: compound 3.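

Among these compounds, until this result only hydroxy groups had moved, and it shows that the group ortho to a large group also matters: trifluoromethoxy in place of trifluoromethyl gives a 3.5-fold lower number from compound 2 to compound 4 (0.54 log units; beyond the scatter) in this assay and so a stronger inhibitor. The entering group brings an oxygen, counted as a hydrogen-bond acceptor, but this single pair cannot show whether that oxygen is responsible for the change. Nothing measured among these compounds explains this step.

Going by these compounds, it remains open whether a methoxy group, a chlorine atom or a longer chain such as ethoxy at this position would shift the number in the same direction. On these data alone, it is also open whether trifluoromethoxy would have a similar effect with the hydroxy groups placed as in compound 1 or compound 3.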